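From 2-chloropyridin-3-yl to 2-chlorophenyl in compound 3

The source may report more compounds than this note shows. Statements on the series, on what has been measured and on what is new or still open speak of the compounds shown alone.

In an ADME assay on microsomes from liver (Mus musculus) for metabolic stability, read by LC-MS (on this read-out higher numbers stand for a longer-lived compound and lower numbers for a shorter-lived compound), compound 1 `O=C(Nc1ccc(F)c(-c2nc3ncc(-c4ccc(F)c(F)c4)cc3[nH]2)c1)N1CCCC1` gives 0.08 h. Compound 2 `Cc1nc(C)c(C(=O)Nc2ccc(F)c(-c3nc4ncc(-c5cccnc5Cl)cn4n3)c2)o1` gives > 1.5 h, which is a limit of the assay and not a number. Compound 3 `Cc1nc(C)c(C(=O)Nc2ccc(F)c(-c3nc4ncc(-c5ccccc5Cl)cn4n3)c2)o1` carries 2-chlorophenyl in place of 2-chloropyridin-3-yl on an aromatic carbon. Going by the values given here, no measured pair of compounds shows this swap, so the expectation is loose: a small move toward a shorter half-life, perhaps none beyond the scatter. The expected step is an at least 1.1-fold lower number from compound 2 to compound 3 (0.06 log units; that floor lies within the scatter). The estimated half-life for compound 3 is 1.3 h, with an expected range of 0.6 h to 2.5 h.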

Compound 3, half-life in the Mus musculus assay: > 1.5 h
Compound 3 ended at the assay's limit (the forecaster's own chance of this, stated with the estimate: 40%); middle value at least 1.1-fold (0.06 log units) from the limit.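

No step in the Mus musculus assay can be read from compound 2 to compound 3, because both stop at the assay's limit: the limit of > 1.5 h in the Mus musculus assay, at which 2 of the 3 values shown sit.

In the Mus musculus assay compound 2 gives > 1.5 h as a limit of the assay and not a number. In the Mus musculus assay compound 3 gives > 1.5 h as a limit of the assay and not a number.

The compounds shown leave open whether 2-chlorophenyl in place of 2-chloropyridin-3-yl changes the half-life at all.

In a physicochemical assay for solubility, read by LC-MS, in phosphate buffer, at pH 7.4, tested at 50 uM (a lower number here means a less soluble compound, a higher number a more soluble compound), compound 2 gives 3840 nM and compound 3 gives 1980 nM with 2-chlorophenyl in place of 2-chloropyridin-3-yl. In the physicochemical assay this is a 1.9-fold lower number from compound 2 to compound 3 (0.29 log units; within the scatter) so the two values do not separate.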